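The compounds below may be only part of what the source reports. "The series", "measured", "known", "first", "only" and "open" are said of these compounds alone.

Values in a functional assay on HUVEC cells (Homo sapiens) for antiproliferative activity; on this read-out higher numbers stand for weaker inhibition of growth and lower numbers for stronger inhibition of growth

- compound 1 `COc1cc(/C=C/C(=O)Nc2ccc(NC(=O)[C@@H](O)[C@H](N)CC3CCCCC3)cc2C)cc(OC)c1OC` gives 1800 nM
- compound 2 `COc1cc(/C=C/C(=O)Nc2ccc(NC(=O)[C@@H](O)[C@H](N)CCC3CCCCC3)cc2)cc(OC)c1OC` gives 800 nM

Compound 2 holds the lower number of the two, so it stops growth at the lower concentration, and its gap to compound 1 lies beyond the usual scatter. These two compounds differ in more than one place, so their gap says little about the next change.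

Compound 3 `COc1cc(/C=C/C(=O)Nc2ccc(NC(=O)[C@@H](O)[C@H](N)CCc3ccccc3)cc2)cc(OC)c1OC` departs from compound 2 in one place (phenyl in place of cyclohexyl on a saturated chain carbon, three bonds along the chain from an amine nitrogen), with phenyl in place of cyclohexyl on a saturated chain carbon, three bonds along the chain from an amine nitrogen. For the measured compounds named here, no measured pair shows this swap alone, so the expectation rests on compound 2 (800 nM) as the closest guide. In this assay the expected change (a 1.3-fold higher number from compound 2 to compound 3 (0.10 log units; within the scatter)) is small, with no step beyond the scatter. The estimate for compound 3 is 1000 nM in a range from 350 nM to 3000 nM as expected here.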

Compound 3, concentration for 50% growth inhibition: 850 nM
Compound 3: the middle estimate sits 1.2-fold (0.07 log units) above what was measured, and the stated range covers the measured number.
By their numbers in this assay, from the lowest: compounds 2 and 3 (each within the scatter of the next); then compound 1.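

Phenyl in place of cyclohexyl on a saturated chain carbon, three bonds along the chain from an amine nitrogen, is the first single swap that can be read in this assay, and it comes to a 1.1-fold higher number from compound 2 to compound 3 (0.03 log units; within the scatter) and nothing more. At this place, then, a non-aromatic and an aromatic six-membered ring of carbon cannot be told apart by this read-out, something the earlier pair, which differs in more than one place, could not show. Nothing at hand accounts for this result.

As far as these compounds go, it remains open whether a pyridyl ring, a piperidinyl ring or an open alkyl chain at this place would also stay within the scatter of compound 2. From the compounds shown here alone, whether benzyl in place of cyclohexylmethyl on compound 1 would give a similarly small step is also open.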